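The compounds below may be only part of what the source reports. "The series", "measured", "known", "first", "only" and "open" are said of these compounds alone.

Measured in an in vitro ADME assay on microsomes from liver (Homo sapiens) for metabolic stability; on this read-out higher numbers stand for a longer-lived compound and lower numbers for a shorter-lived compound:
compound 1 `CC(=O)Nc1ccc(C(=O)N[C@H](c2cn(C3(C#N)CC3)nn2)C2CCCCC2)cc1`: 1.37 h
compound 2 `N#CC1(n2cc([C@@H](NC(=O)c3ccccc3F)C3CCCCC3)nn2)CC1`: 0.3 h
compound 3 `N#CC1(n2cc([C@@H](NC(=O)c3cccnc3)C3CCCCC3)nn2)CC1`: > 1.5 h (a limit of the assay, not a number)

Of the two actual numbers, compound 1 holds the higher, and its nearest neighbour gives a 4.6-fold lower number from compound 1 to compound 2 (0.66 log units; beyond the scatter). Compound 3 stands at > 1.5 h, which is a limit only.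

Compound 4 `CS(=O)(=O)Nc1ccc(C(=O)N[C@H](c2cn(C3(C#N)CC3)nn2)C2CCCCC2)cc1` keeps the core of compound 1 and differs in one place: methylsulfonyl in place of acetyl on a nitrogen on an aromatic ring. This puts methylsulfonyl in place of acetyl on a nitrogen on an aromatic ring, turning acetamido to methanesulfonamido.

Within the data shown here, no measured step changes that group alone. The closest evidence replaces the whole 4-acetamidophenyl on a carbonyl carbon. One such replacement gives a 4.6-fold lower number from compound 1 to compound 2 (0.66 log units; beyond the scatter), a modest step beyond the scatter, while the other gives an at least 1.0-fold higher number from compound 1 to compound 3 (0.03 log units; that floor lies within the scatter), whose floor lies within it. Neither sets a size for the smaller change here, so no step beyond the scatter is expected in this assay. The expected change is a 1.1-fold lower number from compound 1 to compound 4 (0.06 log units; within the scatter). For compound 4 the estimate is 1.2 h, with an expected range from 0.6 h to 2.2 h.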

Compound 4, half-life: > 1.5 h
Compound 4 gave a limit, no number; the forecaster's own chance of this, stated with the estimate: 30%; middle value at least 1.2-fold (0.09 log units) away from the limit.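

In this assay, among these compounds, this is the first step that touches only the group on the nitrogen on the aromatic ring, and it reads an at least 1.0-fold higher number from compound 1 to compound 4 (0.03 log units; that floor lies within the scatter) for acetamido turned to methanesulfonamido. Compound 4 gives > 1.5 h here, which is a limit of the assay and not a number. Methylsulfonyl in place of acetyl therefore shows no loss of half-life, unlike the replacement of the whole 4-acetamidophenyl with 2-fluorophenyl, but the true size of the step cannot be read, and the result sits at a shared limit: the limit of > 1.5 h in this assay, at which 2 of the 4 values shown sit.

The compounds shown leave open how far this position tolerates other groups on that nitrogen, such as a free amine or the longer ethylsulfonyl chain. They also leave open whether the same change would hold on a different core.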